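This account rests on a few compounds, and the source may have more. Where it says the series, first, only, none or still open, it means among the compounds named here.

Compounds measured in a physicochemical assay for solubility; on this read-out higher numbers stand for higher solubility and lower numbers for lower solubility:
- Compound 1 `O=C(c1ccccc1)N1CCC(NS(=O)(=O)c2cc(S(=O)(=O)c3ccccc3)ccc2C(F)(F)F)CC1`: 12500 nM
- Compound 2 `O=C(c1ccc(C(F)(F)F)cc1)N1CCC(NS(=O)(=O)c2cc(S(=O)(=O)c3ccccc3)ccc2C(F)(F)F)CC1`: 6300 nM
- Compound 3 `O=C(c1ccc(Cl)nc1)N1CCC(NS(=O)(=O)c2cc(S(=O)(=O)c3ccccc3)ccc2C(F)(F)F)CC1`: 25000 nM

Compound 3 cannot be told apart from one of the other two, a 2.0-fold higher number from compound 1 to compound 3 (0.30 log units; within the scatter), but it stands clear of the remaining one, a 4.0-fold higher number from compound 2 to compound 3 (0.60 log units; beyond the scatter). In compound 4 `CC(C)(C)OC(=O)N1CC[C@H](C(=O)N2CCC(NS(=O)(=O)c3cc(S(=O)(=O)c4ccccc4)ccc3C(F)(F)F)CC2)C1`, 1-(tert-butoxycarbonyl)pyrrolidin-3-yl takes the place of 6-chloropyridin-3-yl on a carbonyl carbon: 1-(tert-butoxycarbonyl)pyrrolidin-3-yl in place of 6-chloropyridin-3-yl on a carbonyl carbon.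

The closest evidence comes from the changes already measured in the group on that carbonyl carbon. Besides the two steps above, there is a 2.0-fold lower number from compound 1 to compound 2 (0.30 log units; within the scatter). For the measured compounds named here, only the step to compound 3 from compound 2 goes beyond the scatter, and it is modest. Going by the values given here, all three steps involve aromatic groups, however, and no measured compound carries a non-aromatic ring there, so this guide is weak. A small downward step in this assay is expected, with no change beyond the scatter. The expected step is a 2.0-fold lower number from compound 3 to compound 4 (0.30 log units; within the scatter). Compound 4 is estimated at 12500 nM, with an expected range of 4000 nM to 40000 nM.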

Compound 4, solubility: 25000 nM
Estimate against measurement, compound 4: 2.0-fold (0.30 log units) below; the measured number falls inside the stated range.
By their numbers in this assay, from the lowest: compounds 2, 1, 3 and 4 (each within the scatter of the next, the first and the last beyond it).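

In this assay this position on the carbonyl carbon takes a non-aromatic ring as readily as an aromatic one: 1-(tert-butoxycarbonyl)pyrrolidin-3-yl in place of 6-chloropyridin-3-yl gives no change at the digits printed from compound 3 to compound 4 (within the scatter) and so sets a larger, non-aromatic group level with the chloropyridine. Against the other aromatic groups, the same change shows a 2.0-fold higher number from compound 1 to compound 4 (0.30 log units; within the scatter) when phenyl leaves and a 4.0-fold higher number from compound 2 to compound 4 (0.60 log units; beyond the scatter) when 4-(trifluoromethyl)phenyl leaves, and only this last step stands clear of the scatter. No separate measurement is available to explain these numbers.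

The compounds shown cannot separate the part played by the pyrrolidine ring from that of the tert-butoxycarbonyl group. On these data alone, how a free ring amine, a carboxylic acid or the opposite stereocentre would read in this assay also remains open.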